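The source may report more compounds than this note shows. Statements on the series, on what has been measured and on what is new or still open speak of the compounds shown alone.

Three compounds were measured in a functional assay on MCF7 cells (Homo sapiens) for antiproliferative activity, read by MTT assay, with a stated time of 48 h; a higher number here means a weaker inhibitor of growth, a lower number a stronger inhibitor of growth. Compound 1 `CCOc1cc(NC(=O)CCCCCCC(=O)Nc2ccccc2N)cc2c1OCC([N+](=O)[O-])=C2` gives 13500 nM. Compound 2 `CCOc1cc(NC(=O)CCCCCCC(=O)Nc2cc(-c3ccc(C)s3)ccc2N)cc2c1OCC([N+](=O)[O-])=C2` gives 5330 nM. Compound 3 `CCOc1cc(NC(=O)CCCCC(=O)Nc2cc(-c3ccc(C)s3)ccc2N)cc2c1OCC([N+](=O)[O-])=C2` gives 7910 nM; against compound 2 it stands within the scatter, and against compound 1 it also stands within the scatter, so no order among these three can be drawn from compound 3 alone. The cores of compound 2 and compound 3 differ, but the difference between the two cores is not broken down here.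

Within the data shown here, the one counted change that is measured is hydrogen in place of 5-methylthiophen-2-yl on an aromatic carbon, which produced a 2.5-fold higher number from compound 2 to compound 1 (0.40 log units; beyond the scatter). The same change, (hydrogen in place of 5-methylthiophen-2-yl on an aromatic carbon), leads from compound 3 to the unmeasured compound 4 `CCOc1cc(NC(=O)CCCCC(=O)Nc2ccccc2N)cc2c1OCC([N+](=O)[O-])=C2`; the place of the change is the same in both pairs.

Resting on that single measured step, compound 4 is expected to show a 2.4-fold higher number from compound 3 to compound 4 (0.38 log units; beyond the scatter) in this assay, because compound 1 followed compound 2 with a 2.5-fold higher number from compound 2 to compound 1 (0.40 log units; beyond the scatter). Compound 4 is therefore estimated at 19000 nM, within 8500 nM to 42000 nM, though with one prior example the expectation is loose.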

Compound 4, concentration for 50% growth inhibition: 17300 nM
For compound 4 the middle estimate is 1.1-fold (0.04 log units) above the measured one; measured number inside the range.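

In this assay, hydrogen in place of 5-methylthiophen-2-yl gave a 2.2-fold higher number from compound 3 to compound 4 (0.34 log units; beyond the scatter), and this step agrees with the earlier one: the same change on two cores in this assay, a 2.5-fold higher number (0.40 log units; beyond the scatter) from compound 2 to compound 1 and a 2.2-fold higher number (0.34 log units; beyond the scatter) from compound 3 to compound 4, 1.2-fold (0.06 log units) apart, within the scatter of two such steps Across these two pairs, then, the change carried from the core of compound 2 to the core of compound 3 with its direction and its size preserved, and the loss of the 5-methylthiophen-2-yl group cost about the same on both. Among these compounds, this rests on only two cores and one cell assay, so it does not show that the step would hold on any other core, nor does it explain why the group has this effect on growth inhibition.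

The compounds shown leave open whether a simple phenyl ring, an unsubstituted thiophene or a single fluorine on the same aromatic carbon would give a similar step. They also leave open whether the step would persist with a different linking chain, such as a longer one, or with a nitrile in place of the nitro group.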